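The source may report more compounds than this note shows. Statements on the series, on what has been measured and on what is new or still open speak of the compounds shown alone.

Compound 1 `Cc1ccc(S(=O)(=O)Cc2nc(C)n(C)c2[N+](=O)[O-])cc1`: 242000 nM
Compound 2 `Cc1nc(CS(=O)(=O)c2ccccc2)c([N+](=O)[O-])n1CC(C)O`: 418000 nM

In an ADME assay on THP-1 cells (Homo sapiens) for cytotoxicity, read by flow cytometry and propidium iodide staining, with a stated time of 72 h (on this read-out higher numbers stand for weaker inhibition and lower numbers for stronger inhibition), compound 2 gives 418000 nM and compound 1 gives 242000 nM. Going by the values given here, these two values lie within the scatter of each other, so compound 2 does not stand apart from compound 1 on the numbers so far.

Compound 3 `Cc1ccc(S(=O)(=O)Cc2nc(C)n(CC(C)O)c2[N+](=O)[O-])cc1` departs from compound 2 by methyl in place of hydrogen on an aromatic carbon. Among the compounds with values here, no measured pair shows this change alone, so no direct precedent exists for its size or direction. The working expectation in this assay is no step beyond the scatter, with no direction favoured. The expected change is a 1.3-fold lower number from compound 2 to compound 3 (0.10 log units; within the scatter). For compound 3 the estimated value is 330000 nM, with an expected range of 170000 nM to 650000 nM.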

Compound 3, half-maximal inhibitory concentration: > 707000 nM
Compound 3: no number, only a limit; the forecaster's own chance of this, stated with the estimate: 10%; at least 2.1-fold (0.33 log units) between middle value and limit.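

In this assay compound 3 gives > 707000 nM, which is a limit and not a number. Methyl in place of hydrogen on an aromatic carbon, phenyl to 4-methylphenyl, gives an at least 1.6-fold higher number from compound 2 to compound 3 (0.22 log units; that floor lies within the scatter), a floor that does not settle whether this change moves the read-out at all. 1-Hydroxyethyl in place of hydrogen on a saturated chain carbon bound to an aromatic nitrogen gives an at least 2.9-fold higher number from compound 1 to compound 3 (0.46 log units; beyond the scatter), the only step shown beyond the scatter, pointing toward weaker inhibition, and both floors rest on the same ceiling: the limit of > 707000 nM in this assay, at which 1 of the 3 values shown sits.

From the compounds shown here alone, the true size of both steps stays open. Also open, going by these compounds, is whether an amine or a carboxylic acid in place of the methyl on the six-membered ring, or a longer chain in place of the 1-hydroxyethyl, would give a value inside the measurable range.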